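A Methoxy Analogue Expected to Stay at the Limit

The source may report more compounds than this note shows. Statements on the series, on what has been measured and on what is new or still open speak of the compounds shown alone.

Measured so far:
Compound 1, `CC1(c2ccccc2)CC(=O)C(C2CC(c3ccc(OCc4ccc(C(F)(F)F)cc4)cc3)Cc3ccccc32)=C(O)O1`: in a functional assay on HCT-15 cells (Homo sapiens) for inhibition, with a stated time of 72 h (a lower number here means a stronger inhibitor, a higher number a weaker inhibitor), compound 1 gives > 10000 nM, which is a limit of the assay.
Compound 2, `COc1ccc(C2Cc3ccccc3C(C3=C(O)OC(C)(c4ccccc4)CC3=O)C2)cc1`: compound 2 gives > 10000 nM, also a limit.
Compound 3, `CCC1(c2ccccc2)CC(=O)C(C2CC(c3ccc(OCc4ccc(C(F)(F)F)cc4)cc3)Cc3ccccc32)=C(O)O1`: compound 3 gives > 10000 nM, again a limit.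

All three values sit at the same limit (the limit of > 10000 nM in this assay, at which 3 of the 3 values shown sit). From compound 1 to compound 2 the change is hydrogen in place of 4-(trifluoromethyl)phenyl on a saturated chain carbon bound to an oxygen on an aromatic ring, and the step it made is a step that the two limits leave unreadable from compound 1 to compound 2. Compound 4, `CCC1(c2ccccc2)CC(=O)C(C2CC(c3ccc(OC)cc3)Cc3ccccc32)=C(O)O1`, carries the same change made from compound 3: hydrogen in place of 4-(trifluoromethyl)phenyl on a saturated chain carbon bound to an oxygen on an aromatic ring. The two cores differ by methyl in place of hydrogen on a saturated chain carbon bound to a saturated ring carbon. Since compound 3 itself shows only the limit > 10000 nM and the earlier step that the two limits leave unreadable from compound 1 to compound 2 gave no readable size, the step to compound 4 is expected to be a step that the limit leaves unreadable from compound 3 to compound 4, resting on nothing more than those two facts. In this assay compound 4 is expected to sit at 20000 nM, most likely again reported only as a limit.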

Compound 4, half-maximal inhibitory concentration: > 10000 nM
Compound 4: a limit, no number; the forecaster's own chance of this, stated with the estimate: 85%; the middle value lies beyond the limit too.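

Compound 4 gives only a limit, so its steps from compound 3 and from compound 2 cannot be read: the limit of > 10000 nM in this assay, at which 4 of the 4 values shown sit. How strongly any of these compounds inhibits, and what either change does to that, stays open.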